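The compounds below may be only part of what the source reports. "The series", "measured", "known", "first", "only" and "open" are said of these compounds alone.

Compounds measured so far:
- Compound 1 `O=C([C@@H]1CCCN(S(=O)(=O)c2ccc(S(=O)(=O)C3CCC3)cc2)C1)N1CCC(F)(F)CC1`: 9 nM
- Compound 2 `O=C([C@@H]1CCCN(S(=O)(=O)c2ccc(S(=O)(=O)C3CC3)cc2)C1)N1CCC(F)(F)CC1`: 26 nM

Both were tested in a functional assay on MIA PaCa-2 cells (Homo sapiens) for inhibition, read by MTT assay, with a stated time of 7 days; on this read-out higher numbers stand for weaker inhibition and lower numbers for stronger inhibition. Compound 2 gives the higher of the two numbers, the only step shown being a 2.9-fold higher number from compound 1 to compound 2 (0.46 log units; beyond the scatter). Compound 3 `CN(C)S(=O)(=O)c1ccc(S(=O)(=O)N2CCC[C@@H](C(=O)N3CCC(F)(F)CC3)C2)cc1` differs from compound 2 by dimethylamino in place of cyclopropyl on a sulfonyl sulfur. Among the compounds with values here, no measured step swaps a ring on the sulfonyl sulfur for a non-ring group; the one step available concerns ring size only, so the expectation rests on little. A small change or none beyond the scatter is expected: a 1.5-fold higher number from compound 2 to compound 3 (0.19 log units; within the scatter). Compound 3 is estimated at 40 nM, within 12 nM to 130 nM.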

Compound 3, half-maximal inhibitory concentration: 118 nM
Compound 3: the middle estimate sits 3.0-fold (0.47 log units) below what was measured, within the range that was stated.
By their numbers in this assay, from the lowest: compound 1; then compound 2; then compound 3.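

The earlier compounds shown here differed only in ring size on the sulfonyl sulfur. Here, dimethylamino, which has no ring and carries a nitrogen, replaces cyclopropyl with the same count of heavy atoms, and inhibition still weakens, with a 4.5-fold higher number from compound 2 to compound 3 (0.66 log units; beyond the scatter) in this assay and a 13-fold higher number from compound 1 to compound 3 (1.12 log units; beyond the scatter) against the cyclobutyl compound. Nothing measured here explains this loss.

Whether the loss comes from the nitrogen or from opening the ring stays unresolved; isopropyl, with carbon only and no ring, would separate the two. Going by these compounds, whether a larger ring such as cyclopentyl continues the cyclobutyl result also remains open.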